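The source may hold more compounds than are shown below. What is called first, only, known or untested is meant among the compounds shown, and "the series" means these compounds.

Measured in a functional assay on cells (Erythrocyte, Rattus norvegicus) for inhibition, read by hemolysis, with a stated time of 1 h; on this read-out lower numbers stand for stronger inhibition and higher numbers for weaker inhibition
- compound 1 `COc1ccc(C(=O)/C=C/c2cc(OC)c(OC)cc2OC)cc1` gives 2.18 ug/mL
- compound 2 `COc1cc(OC)c(OC)cc1/C=C/C(=O)c1ccccc1` gives 2.23 ug/mL
- compound 3 `COc1cc(OC)c(OC)cc1/C=C/C(=O)c1ccc(-c2c[nH]cn2)cc1` gives 2.48 ug/mL

Compound 2 stands level with both neighbours, as shown by a 1.0-fold higher number from compound 1 to compound 2 (0.01 log units; within the scatter) and a 1.1-fold higher number from compound 2 to compound 3 (0.05 log units; within the scatter). Still unmeasured, compound 4 `COc1cc(OC)c(OC)cc1/C=C/C(=O)c1cc(Cl)ccc1O` differs from it by 5-chloro-2-hydroxyphenyl in place of phenyl on a carbonyl carbon, with 5-chloro-2-hydroxyphenyl in place of phenyl on a carbonyl carbon. The nearest evidence is the substitution on that phenyl in compound 1 and compound 3, where a 1.1-fold higher number from compound 1 to compound 3 (0.06 log units; within the scatter) is also small. None of these steps tests chlorine or hydroxy, so the basis is thin. No shift beyond the scatter is expected, and the estimated move is a 1.0-fold lower number from compound 2 to compound 4 (0.01 log units; within the scatter). For compound 4 the estimate is 2.2 ug/mL, with an expected range of 1.1 ug/mL to 4.4 ug/mL.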

Compound 4, half-maximal inhibitory concentration: 2.23 ug/mL
Estimate against measurement, compound 4: 1.0-fold (0.01 log units) below; low and high end bracket the measured number.
By their numbers in this assay, from the lowest: compounds 1, 2, 4 and 3 (each within the scatter of the next).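

In this assay, among the compounds shown here, chlorine and hydroxy enter together on the phenyl at the carbonyl carbon, a substitution the earlier compounds did not test, and the step reads no change at the digits printed from compound 2 to compound 4 (within the scatter) at this position. Set against the 4-methoxyphenyl, the step reads a 1.0-fold higher number from compound 1 to compound 4 (0.01 log units; within the scatter) and also stays within the scatter. Nothing available explains this flat result.

The separate contributions of chlorine and hydroxy remain unresolved, since they appear only together. Also open, from the compounds shown here alone, is whether an amine or a carboxylic acid on this phenyl would stay within the scatter.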